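The compounds below may be only part of what the source reports. "The series", "measured", "known", "first", "only" and "open" are said of these compounds alone.

Compound 3 `COc1ccc(Sc2nc3cc(N)cc(N)c3nc2-c2ccccc2)cc1` has the highest number of the three compounds measured in a functional assay on LOX IMVI cells (Homo sapiens) for inhibition, read by sulforhodamine B assay, with a stated time of 48 h; on this read-out lower numbers stand for stronger inhibition of growth and higher numbers for weaker inhibition of growth: compound 3 gives 51300 nM, while compound 2 `COc1ccc(CNc2nc3cc(N)cc(N)c3nc2-c2ccccc2)cc1` gives 13500 nM and compound 1 `Nc1cc(N)c2nc(-c3ccccc3)c(NCc3ccc(F)cc3)nc2c1` gives 1510 nM. Compound 4 `Nc1cc(N)c2nc(-c3ccccc3)c(Oc3ccc(F)cc3)nc2c1` differs from compound 3 in one place: 4-fluorophenoxy in place of (4-methoxyphenyl)sulfanyl on an aromatic carbon, the place being an aromatic carbon of the shared core, next to the ring nitrogen. Among the compounds with values here, two measured steps bear on this change. The step of a 34-fold higher number from compound 1 to compound 3 (1.53 log units; beyond the scatter) carries the whole swap of the (4-fluorobenzyl)amino group for the (4-methoxyphenyl)sulfanyl group, and the step of an 8.9-fold higher number from compound 1 to compound 2 (0.95 log units; beyond the scatter) shows that a methoxy in place of a fluoro went with a higher number; compound 4 carries the fluoro again. On that basis compound 4 is expected to come out with a lower number than compound 3, by a step estimated as a 6.4-fold lower number from compound 3 to compound 4 (0.81 log units; beyond the scatter). The estimate for compound 4 in this assay is 8000 nM, in a range from 1500 nM to 40000 nM.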

Compound 4, concentration for 50% growth inhibition: 43700 nM
Beside the measured number, compound 4's estimate is 5.5-fold (0.74 log units) below it; measured number above the stated range.
By their numbers in this assay, from the lowest: compound 1; then compound 2; then compounds 4 and 3 (each within the scatter of the next).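

In this assay, the step to the 4-fluorophenoxy group is a 1.2-fold lower number from compound 3 to compound 4 (0.07 log units; within the scatter), so in this pair the fluoro brings none of the gain that went with it in the pair of benzylamino compounds. The step of a 29-fold higher number from compound 1 to compound 4 (1.46 log units; beyond the scatter) keeps a 4-fluorophenyl ring at this aromatic carbon and shows that the fluoro alone does not hold the low number of compound 1; among the compounds shown, that number stands with the (4-fluorobenzyl)amino group. Nothing given here accounts for this difference.

The compounds shown leave open whether the linking atoms or the ring substituent matter more, as the oxygen-linked and sulfur-linked groups differ in both. They also leave open how a morpholine, a piperazine or a longer amine chain at this place would compare with the (4-fluorobenzyl)amino group.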